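This account rests on a few compounds, and the source may have more. Where it says the series, first, only, none or still open, it means among the compounds named here.

In a functional assay on MDA-MB-231 cells (Homo sapiens) for cytotoxicity, read by MTT assay, with a stated time of 72 h (a lower number here means a stronger inhibitor, a higher number a weaker inhibitor), the measured compounds read:
Compound 1 `CCN(CC)Cc1ccc2nc(NC(=O)N/N=C/c3cn(Cc4ccc(C)cc4)c4ccccc34)sc2c1` gives 2010 nM
Compound 2 `CN(C)Cc1ccc2nc(NC(=O)N/N=C/c3cn(Cc4ccccc4)c4ccccc34)sc2c1` gives 1340 nM

Going by the values given here, compound 2, at 1340 nM in this read-out, stands within the scatter of compound 1, its only neighbour, so the two values cannot be separated. Compound 3 `Cc1ccc(Cn2cc(/C=N/NC(=O)Nc3nc4ccc(CN(C)C)cc4s3)c3ccccc32)cc1` is compound 2 with methyl in place of hydrogen on an aromatic carbon, para to a large group, which turns benzyl into 4-methylbenzyl (methyl in place of hydrogen on an aromatic carbon). No step between measured compounds that differ in one place exists yet, so the size of this change is not shown directly. Compound 1 also carries 4-methylbenzyl, and its 2010 nM stays within the scatter of compound 2. No change beyond the scatter is therefore expected in this assay and the estimated step of a 1.2-fold higher number from compound 2 to compound 3 (0.08 log units; within the scatter) is small. For compound 3 the estimated value is 1600 nM (expected range 700 nM to 3500 nM).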

Compound 3, half-maximal inhibitory concentration: 1220 nM
Compound 3: middle estimate off by 1.3-fold (0.12 log units), on the high side; the measured number falls inside the stated range.
By their numbers in this assay, from the lowest: compounds 3, 2 and 1 (each within the scatter of the next).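

In this assay, the change from benzyl to 4-methylbenzyl now has a direct reading, with a 1.1-fold lower number from compound 2 to compound 3 (0.04 log units; within the scatter) as its size, and the two groups cannot be separated at this position. With 4-methylbenzyl held constant, dimethylamino in place of diethylamino on a saturated chain carbon bound to an aromatic carbon gives a 1.6-fold lower number from compound 1 to compound 3 (0.22 log units; within the scatter) as its step, so this change also stays within the scatter. No measurement is available that bears on the reason for either result.

From the compounds shown here alone, whether chloro, methoxy or a carboxylic acid in place of the methyl would move the number beyond the scatter remains open. Going by these compounds, the same question stands at the other end of the molecule, where the effect of a morpholine or a longer chain in place of dimethylamino is unknown.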